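Capping the Phenol: What to Expect for Compound 4

The source may hold more compounds than are shown below. What is called first, only, known or untested is meant among the compounds shown, and "the series" means these compounds.

Compound 1 `Cc1cc(-c2cccc(O)c2)c2ncc(CSCCc3ccccc3)n2c1` gives 11.4 ug/mL in an ADME assay on HEL cells (Homo sapiens) for cytotoxicity, with a stated time of 3 days; a higher number here means that more compound is tolerated, a lower number that less compound is tolerated.
Compound 2 `Cc1cc(-c2ccccc2)cn2c(CSCCc3ccccc3)cnc12` gives 31 ug/mL.
Compound 3 `Cc1cc(-c2ccc(O)cc2)cn2c(CSCCc3ccccc3)cnc12` gives > 50 ug/mL, which is a limit of the assay and not a number.

Compound 3 therefore stands at the ceiling of what was measured: its reading is the limit of > 50 ug/mL in this assay, at which 1 of the 3 values shown sits, so the true value is only known to lie beyond it. Within the data shown here, the one measured step that bears on the change ahead is an at least 1.6-fold higher number from compound 2 to compound 3 (0.20 log units; that floor lies within the scatter), which adds a hydroxy group to the unsubstituted phenyl ring of compound 2; how much larger than its floor that step really is remains open. Compound 1 and compound 2 differ in more than one place, so their values are simply two readings side by side.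

Compound 4 `COc1ccc(-c2cc(C)c3ncc(CSCCc4ccccc4)n3c2)cc1` differs from compound 3 by methyl in place of hydrogen on an oxygen on an aromatic ring. Among the measured compounds shown here, no measured pair covers a methyl on this oxygen, so the expectation rests on the neighbouring readings: compound 2 without any oxygen substituent gives 31 ug/mL. Compound 3 with the free hydroxy has only a limit reading. Compound 4 is expected to fall near or between these, at an estimated 40 ug/mL with a range from 18 ug/mL to 90 ug/mL. That estimate for compound 4 means an expected step of an at least 1.2-fold lower number from compound 3 to compound 4 (0.09 log units; that floor lies within the scatter), which is not one beyond the scatter.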

Compound 4, half-maximal cytotoxic concentration: 25.8 ug/mL
Estimate against measurement, compound 4: 1.6-fold (0.19 log units) above; the range from low to high includes it.
By their numbers in this assay, from the lowest: compound 1; then compounds 4 and 2 (each within the scatter of the next). At a limit, above all of these: compound 3.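

Putting methyl on the oxygen of the 4-hydroxyphenyl group gives an at least 1.9-fold lower number from compound 3 to compound 4 (0.28 log units; that floor lies within the scatter), and the real size of this step stays unknown because the reading of compound 3 is a limit and not a number: the limit of > 50 ug/mL in this assay, at which 1 of the 4 values shown sits.

Measured against the unsubstituted phenyl ring, the same group gives a 1.2-fold lower number from compound 2 to compound 4 (0.08 log units; within the scatter), so in this assay adding methoxy in place of hydrogen on this aromatic carbon produces no difference that can be told apart from the scatter. Among these compounds, this result therefore gives the first actual number for an oxygen-bearing group at this place on the ring, and that number cannot be distinguished from the one for compound 2, while the free hydroxy of compound 3 remains the only one of these three compounds with a reading at a limit.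

The compounds shown leave open how far the reading of compound 3 truly lies from those of compound 2 and compound 4, so the effect of capping the hydroxy has no upper bound yet. They also leave open whether a longer chain on this oxygen, such as ethoxy, or an amine or a carboxylic acid in place of the hydroxy, would give a reading that stands apart from these.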